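The compounds below may be only part of what the source reports. "The series", "measured", "known", "first", "only" and "open" are said of these compounds alone.

Measured so far:
- compound 1, `CCn1nnc(-c2sc(-c3ccc(O)cc3)nc2O)n1`: 11600 nM
- compound 2, `O=C(O)c1sc(-c2ccccc2)nc1O`: > 100000 nM
- compound 3, `CCOC(=O)c1sc(-c2ccccc2)nc1OC`: > 100000 nM

Of the compounds shown here, three have been tested in an assay on HEK293 cells for inhibition of transient receptor potential cation channel subfamily M member 8 (Homo sapiens), read by FLIPR, with stated times of 5 min and 3 min; a higher number here means a weaker inhibitor, a lower number a stronger inhibitor. Compound 1 is the only one of them with an actual number: in this assay compound 1 gives 11600 nM. For compound 2 the result > 100000 nM is a limit of the assay, not a number. For compound 3 the result > 100000 nM is likewise a limit. So compound 1 stands alone as the one measurable inhibitor here, while the other two sit at the limit of > 100000 nM in this assay, at which 2 of the 3 values shown sit. Among the measured compounds shown here, no step between two measured compounds can be worked out, as no pair differs in a single place.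

The next compound, compound 4, `CCn1nnc(-c2sc(-c3ccc(Cl)cc3)nc2O)n1`, differs from compound 1 in one place: chloro in place of hydroxy on an aromatic carbon. For the measured compounds named here, no measured step of this kind exists among the three compounds, so the expectation rests on compound 1 alone. The change from compound 1 to compound 4 is estimated to shift this assay by a 1.0-fold higher number from compound 1 to compound 4 (0.01 log units; within the scatter), a step not clearly beyond the usual scatter in either direction. Compound 4 is therefore expected to give about 12000 nM, somewhere between 3000 nM and 50000 nM.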

Compound 4, half-maximal inhibitory concentration: 7550 nM
For compound 4 the middle estimate is 1.6-fold (0.20 log units) above the measured one; the measured number falls inside the stated range.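

In this assay, among the compounds shown here, chloro in place of hydroxy on the aromatic carbon para to a large group gives a 1.5-fold lower number from compound 1 to compound 4 (0.19 log units; within the scatter), the first step that can be read at this position. A hydroxy with one hydrogen-bond donor and one acceptor can therefore give way to a chloro with neither, and compound 1 and compound 4 still cannot be told apart in this assay. Nothing shown here gives a cause for this outcome, and the single step cannot say why the two compounds read alike.

On these data alone, it remains open whether a different group at this position, such as an amine, a methoxy or a carboxylic acid, would move the number beyond the scatter. A plain hydrogen there would show whether the position needs any group at all.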